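Acylating the ring nitrogen of a thiol carboxypeptidase inhibitor

The compounds below may be only part of what the source reports. "The series", "measured", "known", "first", "only" and "open" are said of these compounds alone.

Compound 1 `O=C(O)C(CS)C1CCNCC1` is tested in an assay on isolated protein for inhibition of carboxypeptidase N catalytic chain (Homo sapiens) (a lower number here means a stronger inhibitor, a higher number a weaker inhibitor), and gives 60 nM. For the measured compounds named here, it is the only compound here with a single value; the two others each have more than one entry. Compound 2 `N=C(N)N1CCCC(C(CS)C(=O)O)C1` gives 58 nM; 38 nM (2 entries), numbers that sit within the usual scatter of the value of compound 1 (the several entries of compound 2 in this assay, 58 nM; 38 nM (2 entries)). Compound 3 `O=C(O)C(CS)C1CCCNC1` gives 1750 nM; 23500 nM (2 entries), both entries far higher than those of compound 1 and compound 2, so compound 3 is the weaker inhibitor here (the several entries of compound 3 in this assay, 1750 nM; 23500 nM (2 entries)). Compound 4 `NCC(=O)N1CCC(C(CS)C(=O)O)CC1` has not yet been measured. It differs from compound 1 in one place: (aminomethyl)carbonyl in place of hydrogen on an amine nitrogen in a ring. Going by the values given here, no measured pair among the three compounds shows what such a change does, so the expectation for compound 4 rests on the numbers above alone. The change is expected to weaken inhibition, with an estimated step from compound 1 to compound 4 of a 10-fold higher number from compound 1 to compound 4 (1.00 log units; beyond the scatter). Compound 4 is therefore estimated at 600 nM, within a range from 150 nM to 4000 nM.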

Compound 4, half-maximal inhibitory concentration: 4950 nM
For compound 4 the middle estimate is 8.3-fold (0.92 log units) below the measured one, outside the stated range (above it).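

Placing (aminomethyl)carbonyl on the amine nitrogen in the ring costs a great deal of inhibition in this assay, with an 83-fold higher number from compound 1 to compound 4 (1.92 log units; beyond the scatter). For the compounds shown here, this is the first direct reading of a change at this nitrogen, as the earlier compounds offered no pair differing in one place. It also shows that the amine carried on the new group does not make up for acylating the ring nitrogen, although nothing measured here explains why the step is so large.

Going by these compounds alone, whether the loss follows the carbonyl or the added amine stays open, as the single new group carries both. A plain acetyl group or a methyl group on the same nitrogen would separate the two, and a longer chain ending in an amine would test the length of the group.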